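Aromatic substituent exchange on the shared core

A few compounds are considered here, and "the series" means these few. Any claim that something is new, unique, unknown or untested is made for them only; others in the source may bear on it.

Compound 1 `CCCS(=O)(=O)Nc1ccc(F)c(C(=O)c2n[nH]c3ncc(-c4ccccc4)cc23)c1F` gives 2.4% in an assay for binding affinity to dual specificity mitogen-activated protein kinase kinase 4 (Homo sapiens), read by KINOMEscan, tested at 100 nM; on this read-out lower numbers stand for a stronger effect and higher numbers for a weaker effect at the one concentration tested. Compound 2 `CCCS(=O)(=O)Nc1ccc(F)c(C(=O)c2n[nH]c3ncc(-c4cccc(F)c4)cc23)c1F` gives 8.2% in this assay, and compound 3 `CCCS(=O)(=O)Nc1ccc(F)c(C(=O)c2n[nH]c3ncc(-c4cccc(OC)c4)cc23)c1F` gives 6.3%. Compound 2 stands within the scatter of both neighbours: a number 5.8 percentage points higher from compound 1 to compound 2 (within the scatter) and a number 1.9 percentage points lower from compound 2 to compound 3 (within the scatter). Compound 4 `CCCS(=O)(=O)Nc1ccc(F)c(C(=O)c2n[nH]c3ncc(-c4ccc(OC)cc4)cc23)c1F` is not yet measured; it differs from compound 2 in one place: 4-methoxyphenyl in place of 3-fluorophenyl on an aromatic carbon. Among the compounds with values here, two measured steps bear on this exchange, methoxy in place of fluoro on an aromatic carbon a number 1.9 percentage points lower from compound 2 to compound 3 (within the scatter) and methoxy in place of hydrogen on an aromatic carbon a number 3.9 percentage points higher from compound 1 to compound 3 (within the scatter), both within the scatter. No step beyond the scatter is therefore expected in this assay for compound 4, the expected step being a number 3.2 percentage points lower from compound 2 to compound 4 (within the scatter). Compound 4 is estimated at 5%, with a range from 1% to 14%.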

Compound 4, a percentage reported as activity, at one concentration (the size of the read-out at that concentration, not a potency): 4.2%
For compound 4 the middle estimate is 0.8 percentage points above the measured one, and the stated range covers the measured number.
By their numbers in this assay, from the lowest: compounds 1, 4, 3 and 2 (each within the scatter of the next).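

In this assay 4-methoxyphenyl in place of 3-methoxyphenyl does not separate the two methoxyphenyl groups (a number 2.1 percentage points lower from compound 3 to compound 4 (within the scatter)). This aromatic carbon also tolerates the exchange of 3-fluorophenyl for 4-methoxyphenyl (a number 4 percentage points lower from compound 2 to compound 4 (within the scatter)), and the step from the unsubstituted phenyl stays equally small (a number 1.8 percentage points higher from compound 1 to compound 4 (within the scatter)). All four aryl groups shown therefore remain indistinguishable at this position, and no evidence is at hand to account for this. From the compounds shown here alone, whether an amine or a carboxylic acid on the phenyl ring, or a longer chain in place of the propyl chain on the sulfonamide, would produce a step beyond the scatter remains open.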